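A few compounds are considered here, and "the series" means these few. Any claim that something is new, unique, unknown or untested is made for them only; others in the source may bear on it.

Measured so far:
compound 1 `COc1nc(OC)c([N+](=O)[O-])c(C(Br)Br)n1` gives 1900000 nM in a functional assay on the whole organism with Mus musculus as the target; on this read-out lower numbers stand for stronger inhibition and higher numbers for weaker inhibition;
compound 2 `CCN(CC)c1nc(OC)nc(C(Br)Br)c1[N+](=O)[O-]` gives 5800000 nM in this assay.

Compound 1 holds the lowest number of the two; compound 2 differs from it by a 3.1-fold higher number from compound 1 to compound 2 (0.48 log units; beyond the scatter). Compound 3 `COc1nc(C(Br)Br)c([N+](=O)[O-])c(N2CCCCC2)n1` differs from compound 1 by piperidin-1-yl in place of methoxy on an aromatic carbon. Going by the values given here, the only step that bears on it is the one from compound 1 to compound 2, also an amine in place of methoxy at the same position, which raised the number modestly. A step of similar size and direction is therefore expected for compound 3, a 2.6-fold higher number from compound 1 to compound 3 (0.42 log units; beyond the scatter). The estimate for compound 3 in this assay is 5000000 nM, within 1500000 nM to 16000000 nM.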

Compound 3, half-maximal inhibitory concentration: 540000 nM
Beside the measured number, compound 3's estimate is 9.3-fold (0.97 log units) above it; the whole stated range lies above it.
By their numbers in this assay, from the lowest: compound 3; then compound 1; then compound 2.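

In this assay, replacing methoxy with an amine at this position has no single direction: with piperidin-1-yl the step is downward (a 3.5-fold lower number from compound 1 to compound 3 (0.55 log units; beyond the scatter)), the opposite of the rise seen with diethylamino in compound 2. The identity of the amine therefore matters here, as exchanging diethylamino for piperidin-1-yl gives the largest step in the set (an 11-fold lower number from compound 2 to compound 3 (1.03 log units; beyond the scatter)). Nothing available explains this difference between the two amines.

From the compounds shown here alone, whether morpholine or pyrrolidine would follow compound 3 remains open. So does whether an open-chain amine such as dimethylamino would follow compound 2.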